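Moving a Side Group Around a Pyrrolidine Ring

This account rests on a few compounds, and the source may have more. Where it says the series, first, only, none or still open, it means among the compounds named here.

Of the compounds shown here, three have been measured in an assay on isolated protein for inhibition of serine/threonine-protein kinase Chk2 (Homo sapiens); a higher number here means a weaker inhibitor, a lower number a stronger inhibitor. Compound 1 `CC(C)(O)[C@@H]1CNC[C@H]1Nc1nc(-c2cc(F)ccc2O)nc2ccccc12` gives 21 nM, the lowest of the three numbers. Compound 2 `COc1cc2nc(-c3ccccc3O)nc(N[C@H]3CCNC3)c2cc1OC` gives 28 nM, which sits within the scatter of compound 1, so the two cannot be told apart. Compound 3 `Cc1ccc(O)c(-c2nc(N[C@H]3CCNC3)c3ccccc3n2)c1` gives 92 nM, a gap from compound 1 that lies beyond the scatter.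

Compound 4 `CC(C)(O)[C@H]1C[C@H](Nc2nc(-c3cc(F)ccc3O)nc3ccccc23)CN1` is built from the same atoms as compound 1, joined differently: 5-(1-hydroxy-1-methylethyl)pyrrolidin-3-yl in place of 4-(1-hydroxy-1-methylethyl)pyrrolidin-3-yl on a nitrogen on an aromatic ring. Among the measured compounds shown here, no measured pair in this set shows what such a rearrangement does, so the expectation rests on compound 1 alone. Because compound 1 gives 21 nM, compound 4 is expected to stay in the same broad region, with a modest step towards a higher number as the most likely outcome, since the side group now sits elsewhere on the ring. The expected step from compound 1 to compound 4 is a 1.9-fold higher number from compound 1 to compound 4 (0.28 log units; within the scatter). Compound 4 is estimated at 40 nM, with a range from 12 nM to 130 nM.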

Compound 4, half-maximal inhibitory concentration: 460 nM
For compound 4 the middle estimate is 12-fold (1.06 log units) below the measured one; the measured number lies above the stated range.
By their numbers in this assay, from the lowest: compounds 1 and 2 (each within the scatter of the next); then compound 3; then compound 4.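

Among the compounds shown here, replacing 4-(1-hydroxy-1-methylethyl)pyrrolidin-3-yl with 5-(1-hydroxy-1-methylethyl)pyrrolidin-3-yl on the nitrogen gives, in this assay, a 22-fold higher number from compound 1 to compound 4 (1.34 log units; beyond the scatter), a large step that the earlier compounds gave no sign of. The two side groups match in heavy atoms, hydrogen-bond donors and acceptors, and net charge, so in this assay a matching composition does not secure a matching result: how the atoms are joined can matter a great deal. Nothing shown here accounts for the size of this step.

As far as these compounds go, it remains open whether the loss follows the bulky 1-hydroxy-1-methylethyl group itself or any group placed this way, as a smaller hydroxymethyl or methyl group could show. From the compounds shown here alone, the effect of the opposite stereochemistry at the two defined stereocentres also remains open.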